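Thiosemicarbazone from a terpene isothiocyanate: swapping the aryl end

The source may hold more compounds than are shown below. What is called first, only, known or untested is meant among the compounds shown, and "the series" means these compounds.

Compound 1 `CC1=CC[C@H](C(C)(C)N=C=S)CC1`: > 100000 nM
Compound 2 `COc1ccc(/C=N/NC(=S)NC(C)(C)[C@H]2CC=C(C)CC2)cc1`: 47800 nM

In a functional assay on NCI-H460 cells (Homo sapiens) for inhibition, read by sulforhodamine B assay, with a stated time of 48 h (on this read-out higher numbers stand for weaker inhibition of growth and lower numbers for stronger inhibition of growth), compound 1 reaches only a limit, > 100000 nM, and is not a number; it sits at the limit of > 100000 nM in this assay, at which 1 of the 2 values shown sits. In this assay, for the measured compounds named here, compound 2 gives 47800 nM, the only real number among the two measured compounds, so there is nothing to rank it against. Compound 3 `CC1=CC[C@H](C(C)(C)NC(=S)N/N=C/c2cccc(Cl)c2)CC1` is not yet measured. It differs from compound 2 in one place: 3-chlorophenyl in place of 4-methoxyphenyl on a carbon with a double bond to nitrogen. Going by the values given here, no measured pair covers such a change on this series, so the size and direction of the step cannot be read from the data. The aryl end is simply exchanged for another small aryl group, and a step no larger than the usual scatter, in either direction, is the most cautious expectation. For compound 3 the estimated value in this assay is 35000 nM, with a range from 12000 nM to 100000 nM, which is expected to mean a step of a 1.4-fold lower number from compound 2 to compound 3 (0.14 log units; within the scatter).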

Compound 3, concentration for total growth inhibition: 21400 nM
Compound 3: middle estimate off by 1.6-fold (0.21 log units), on the high side; low and high end bracket the measured number.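

In this assay, the aryl end of the thiosemicarbazone proves able to move the number: 3-chlorophenyl in place of 4-methoxyphenyl on a carbon with a double bond to nitrogen gives a 2.2-fold lower number from compound 2 to compound 3 (0.35 log units; beyond the scatter) and so lies beyond the scatter, though the step is modest. For the compounds shown here, this position therefore responds to a change of aryl group, which the earlier compounds could not show. Going by these compounds alone, nothing measured here accounts for the step, and the single exchange alters both the group on the aromatic ring and its place on that ring.

From the compounds shown here alone, whether the step follows the chlorine, its place or the loss of the methoxy group stays open, as does the outcome with an amine or a carboxylic acid on the aryl ring. Compound 1 sits at a limit, > 100000 nM, and offers no number to step from.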